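The source may report more compounds than this note shows. Statements on the series, on what has been measured and on what is new or still open speak of the compounds shown alone.

Measured so far in a functional assay on HeLa cells (Homo sapiens) for antiproliferative activity, read by CCK-8 assay, with a stated time of 72 h, tested at 8 uM; on this read-out lower numbers stand for a weaker effect and higher numbers for a stronger effect at the one concentration tested:

Compound 1, `Nc1ccccc1NC(=O)c1ccc(CSC(=S)N2CCN(Cc3ccncc3)CC2)cc1`, gives 72.9%.
Compound 2, `CN1CCN(C(=S)SCc2ccc(C(=O)Nc3ccccc3N)cc2)CC1`, gives 75.7%.
Compound 3, `Nc1ccccc1NC(=O)c1ccc(CSC(=S)N2CCN(c3ncccn3)CC2)cc1`, gives 73.9%.

All three compounds share one core and differ only in the group carried on the ring nitrogen of the saturated six-membered ring with two nitrogen atoms. On the numbers, compound 3 sits among the other two rather than apart from them: the step of a number 1 percentage points higher from compound 1 to compound 3 (within the scatter) and the step of a number 1.8 percentage points lower from compound 2 to compound 3 (within the scatter) are both within the scatter, and so is a number 2.8 percentage points higher from compound 1 to compound 2 (within the scatter). In other words, none of the three groups tried so far on that nitrogen has moved the read-out in this assay beyond what repeated measurements would show anyway.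

Compound 4, `Nc1ccccc1NC(=O)c1ccc(CSC(=S)N2CCN(c3ccccc3F)CC2)cc1`, has not yet been measured. It differs from compound 3 by 2-fluorophenyl in place of pyrimidin-2-yl on an amine nitrogen in a ring. This is again a change at the same ring nitrogen, and it is the three steps just named that bear on it. Since each of them stayed within the scatter, the expectation is that the step of a number 0.1 percentage points higher from compound 3 to compound 4 (within the scatter) will also stay within the scatter, with no clear direction. Compound 4 is therefore estimated to give 74% in this assay, with a range from 63% to 84%.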

Compound 4, a percentage reported as inhibition, at one concentration (the size of the read-out at that concentration, not a potency): 59.2%
Compound 4: middle estimate off by 14.8 percentage points, on the high side; the whole stated range lies above it.
By their numbers in this assay, from the lowest: compound 4; then compounds 1, 3 and 2 (each within the scatter of the next).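

In this assay, the group on this ring nitrogen can matter after all: 2-fluorophenyl in place of pyrimidin-2-yl gives a number 14.7 percentage points lower from compound 3 to compound 4 (beyond the scatter), and the comparisons with the other two groups agree, with a number 16.5 percentage points lower from compound 2 to compound 4 (beyond the scatter) and a number 13.7 percentage points lower from compound 1 to compound 4 (beyond the scatter). The methyl, (pyridin-4-yl)methyl and pyrimidin-2-yl groups had stayed within the scatter of one another, so the position accepts those three without a clear change, but it does not accept every group equally. Having a six-membered aromatic ring on this nitrogen does not by itself go with the lower number, as compound 3 carries one too; the ring of compound 4 differs in being carbon only, with a fluorine, and in having no hydrogen-bond acceptors where pyrimidin-2-yl has two.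

Nothing available here offers an explanation for this difference. Going by these compounds, whether the lower number goes with the fluorine or with the carbon-only ring stays open, and a plain phenyl group on the same nitrogen would help to separate the two.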